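A few compounds are considered here, and "the series" means these few. Any claim that something is new, unique, unknown or untested is made for them only; others in the source may bear on it.

Measured compounds:
compound 1, `COc1ccc2nc(-c3ccc(N/C=C\C(=O)c4cc(OC)c(OC)c(OC)c4)cc3)sc2c1`: 31100 nM
compound 2, `COc1cc(C(=O)/C=C\Nc2ccc(-c3nc4cc(OC)c(OC)c(OC)c4s3)cc2C)c(Br)c(OC)c1OC`: 24300 nM
compound 3, `COc1ccc2nc(-c3ccc(N/C=C\C(=O)c4cc(OC)c(OC)c(OC)c4Br)cc3)sc2c1`: 14700 nM

In a functional assay on MIA PaCa-2 cells (Homo sapiens) for antiproliferative activity, read by sulforhodamine B assay, with a stated time of 48 h (on this read-out lower numbers stand for stronger inhibition and higher numbers for weaker inhibition), compound 3 gives 14700 nM, and one change, (hydrogen in place of bromo on an aromatic carbon), leads from it to compound 1, with a 2.1-fold higher number from compound 3 to compound 1 (0.33 log units; beyond the scatter). Compound 2 and compound 3 carry different cores; the difference between the two cores is not broken down here. In this assay compound 2 gives 24300 nM, which lies within the scatter of compound 1 and of compound 3 alike. Compound 4, `COc1cc(C(=O)/C=C\Nc2ccc(-c3nc4cc(OC)c(OC)c(OC)c4s3)cc2C)cc(OC)c1OC`, arises from compound 2 by the same change, (hydrogen in place of bromo on an aromatic carbon), at a place described in the same words. Because a 2.1-fold higher number from compound 3 to compound 1 (0.33 log units; beyond the scatter) weakened inhibition modestly, compound 4 is expected to show a step of similar size, a 2.1-fold higher number from compound 2 to compound 4 (0.31 log units; beyond the scatter). Compound 4 is therefore estimated at 50000 nM in this assay, with a likely range from 25000 nM to 100000 nM.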

Compound 4, half-maximal inhibitory concentration: 22800 nM
Compound 4: the middle estimate sits 2.2-fold (0.34 log units) above what was measured, outside the stated range (below it).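

In this assay, hydrogen in place of bromo on an aromatic carbon gives a 1.1-fold lower number from compound 2 to compound 4 (0.03 log units; within the scatter). Set beside the earlier step, this result cannot be separated from it: the same change on two cores in this assay, a 2.1-fold higher number (0.33 log units; beyond the scatter) from compound 3 to compound 1 and a 1.1-fold lower number (0.03 log units; within the scatter) from compound 2 to compound 4, 2.3-fold (0.35 log units) apart, within the scatter of two such steps. The two pairs therefore show no measurable dependence of this change on the core, but they do not show that its effect carries over unchanged, and two pairs are too few to establish a rule for the series.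

The compounds shown leave open how chloro, an amine or a carboxylic acid would read on that aromatic carbon. They also leave open whether the bromo-to-hydrogen step would behave alike on any further core.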